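The source may hold more compounds than are shown below. What is called first, only, known or untested is meant among the compounds shown, and "the series" means these compounds.

Working notes on the series. Compound 1 `COc1ncc(-c2cc(OC3CCC3)c3ncnc(C)c3c2)cc1NS(=O)(=O)c1ccc(F)cc1F` holds the highest number of the three measured in an ADME assay on Caco-2 cells (Homo sapiens) for permeability, read by LC-MS, in the apical to basolateral direction, with a stated time of 90 min (a higher number here means that the compound crosses the layer faster, a lower number that the compound crosses the layer more slowly), giving 44 10^-6 cm/s. Compound 2 `COc1ncc(-c2cc(OC3CCCC3)c3ncnc(C)c3c2)cc1NS(=O)(=O)c1ccc(F)cc1F` gives 28 10^-6 cm/s, and compound 3 `COc1ncc(-c2cc(OCC3CCN(C)CC3)c3ncnc(C)c3c2)cc1NS(=O)(=O)c1ccc(F)cc1F` gives 8.8 10^-6 cm/s. Among the measured steps, a 1.6-fold lower number from compound 1 to compound 2 (0.20 log units; within the scatter), whereas a 5.0-fold lower number from compound 1 to compound 3 (0.70 log units; beyond the scatter) and a 3.2-fold lower number from compound 2 to compound 3 (0.50 log units; beyond the scatter).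

Compound 4 `COc1ncc(-c2cc(OC(F)F)c3ncnc(C)c3c2)cc1NS(=O)(=O)c1ccc(F)cc1F` differs from compound 1 as follows: difluoromethyl in place of cyclobutyl on an oxygen on an aromatic ring. For the measured compounds named here, only the step to compound 2 bears closely on it, since that change also swaps one neutral group on the same oxygen for another neutral group, and it stayed within the scatter; the step to compound 3 introduces a different kind of group and is less informative. A step of no more than modest size is therefore expected in this assay, most likely within the scatter, at a 1.3-fold lower number from compound 1 to compound 4 (0.10 log units; within the scatter). For compound 4 the expected value is 35 10^-6 cm/s, with a range from 18 10^-6 cm/s to 60 10^-6 cm/s.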

Compound 4, apparent permeability: 34 10^-6 cm/s
Compound 4: the middle estimate sits 1.0-fold (0.01 log units) above what was measured; low and high end bracket the measured number.
By their numbers in this assay, from the lowest: compound 3; then compounds 2, 4 and 1 (each within the scatter of the next).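

In this assay, cyclobutyloxy to difluoromethoxy gives a 1.3-fold lower number from compound 1 to compound 4 (0.11 log units; within the scatter), and the cyclopentyl comparison gives a 1.2-fold higher number from compound 2 to compound 4 (0.08 log units; within the scatter), so on this oxygen a fluorinated group without a ring stays level with both carbon rings. The piperidine-bearing group remains apart, with a 3.9-fold higher number from compound 3 to compound 4 (0.59 log units; beyond the scatter), and the earlier separation therefore does not depend on a ring being present in the neutral comparators. No measured evidence bears on the reason for this. On these data alone, whether a carboxylic acid or a longer chain on this oxygen would stay with compound 4 or with compound 3 remains open. The compounds shown also cannot separate the amine of compound 3 from the size of its group.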